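The source may hold more compounds than are shown below. What is called first, only, known or untested is meant among the compounds shown, and "the series" means these compounds.

Values so far in a physicochemical assay for solubility, read by HPLC, using the shake flask method, in phosphate buffer, with a stated time of 20 h, at pH 6.5 (on this read-out higher numbers stand for higher solubility and lower numbers for lower solubility), for the shared series:

- compound 1 `Fc1ccc(-c2nc3c(N4CCCNCC4)nccc3[nH]2)cc1F` gives 165000 nM
- compound 2 `CN1CCN(C(=O)C2CCN(c3nccc4[nH]c(-c5ccc(F)c(F)c5)nc34)CC2)CC1` gives 200000 nM
- compound 3 `CN1CCN(CC2CCN(c3nccc4[nH]c(-c5ccc(F)c(Cl)c5)nc34)CC2)CC1` gives 155000 nM

Compound 3 (155000 nM) lies within the scatter of both compound 1 and compound 2, so the three values sit at one level and none stands apart.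

Compound 4 `CN1CCN(CC2CCN(c3nccc4[nH]c(C5CCCC5)nc34)CC2)CC1` differs from compound 3 by a single change: cyclopentyl in place of 3-chloro-4-fluorophenyl on an aromatic carbon. Going by the values given here, no two measured compounds differ in only one place, so the data give no direct measure of a change like this. Among the compounds with values here, the only guide is the shared level of the three values, including compound 3 (155000 nM). In this assay no step beyond the scatter is expected, with a slight upward lean as the likelier direction. An estimated 1.2-fold higher number from compound 3 to compound 4 (0.09 log units; within the scatter) is expected, staying within the scatter. For compound 4 the expected value is 190000 nM in this read-out, with an estimated range of 110000 nM to 320000 nM for repeat measurements.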

Compound 4, solubility: < 5000 nM
Compound 4: only a limit was reported (the forecaster's own chance of this, stated with the estimate: 15%); middle value at least 38-fold (1.57 log units) from the limit.
By their numbers in this assay, from the lowest: compounds 3, 1 and 2 (each within the scatter of the next). At a limit, below all of these: compound 4.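

Going by these compounds alone, at this position, on an aromatic carbon of a five-membered aromatic ring with 2 nitrogen, cyclopentyl in place of 3-chloro-4-fluorophenyl gives the only one-place step in this assay: an at least 31-fold lower number from compound 3 to compound 4 (1.49 log units; beyond the scatter). Compound 4 reads < 5000 nM in this assay, which is a limit and not a number: the limit of < 5000 nM in this assay, at which 1 of the 4 values shown sits.

Within the data shown here, the read-out is therefore not indifferent to the group at this position, something the earlier compounds, with no one-place pair among them, could not show.

This single pair does not separate the loss of the aromatic ring from the loss of the chlorine and fluorine. Unsubstituted phenyl or cyclohexyl at the same place would tell these apart, and neither is among the compounds shown.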